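The source may hold more compounds than are shown below. What is called first, only, known or untested is meant among the compounds shown, and "the series" means these compounds.

The series shares one core, shown in compound 1 `Cc1ccc(/C=C2\CN(C(=S)SCc3cn(Cc4ccccc4F)nn3)C/C(=C\c3ccc(C)cc3)C2=O)cc1`, compound 2 `Cc1ccc(/C=C2\CN(Cc3cn(Cc4cccc(Cl)c4)nn3)C/C(=C\c3ccc(C)cc3)C2=O)cc1` and compound 3 `COc1ccc(/C=C2\CN(Cc3cn(Cc4cccc(Cl)c4)nn3)C/C(=C\c3ccc(OC)cc3)C2=O)cc1`, and each was tested in a functional assay on 4T1 cells (Mus musculus) for cytotoxicity, read by MTT assay, with a stated time of 24 h; on this read-out lower numbers stand for stronger inhibition and higher numbers for weaker inhibition. Compound 1 gives 28400 nM in this assay. Compound 2 gives 29300 nM, and compound 3 gives 56600 nM. Among these three numbers compound 2 stands second highest, but its nearest neighbour, compound 1, and its furthest, compound 3, both sit within the usual scatter of it, so nothing in this set separates compound 2 from the others. Among the measured compounds shown here, no two measured compounds differ in a single place, so no step can be read off directly.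

Compound 4 `Cc1ccc(/C=C2\CN(Cc3cn(Cc4ccccc4F)nn3)C/C(=C\c3ccc(C)cc3)C2=O)cc1` has not been measured. It differs from compound 2 by 2-fluorophenyl in place of 3-chlorophenyl on a saturated chain carbon bound to an aromatic nitrogen. For the measured compounds named here, the only other compound carrying a 2-fluorobenzyl group is compound 1, and it differs from compound 4 in a second place. In this assay, going by the values given here, compound 1 gives 28400 nM, which shows only that this group is compatible with a number close to that of compound 2.

From compound 2 the step is expected to be a 1.0-fold higher number from compound 2 to compound 4 (0.01 log units; within the scatter), that is, no change beyond the scatter. Compound 4 is therefore estimated at 30000 nM, with a range from 14000 nM to 64000 nM.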

Compound 4, half-maximal inhibitory concentration: 18000 nM
The estimate for compound 4 lay 1.7-fold (0.22 log units) above the measured number, within the range that was stated.
By their numbers in this assay, from the lowest: compounds 4, 1, 2 and 3 (each within the scatter of the next, the first and the last beyond it).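

In this assay, among the compounds shown here, the first direct step at this position, a 1.6-fold lower number from compound 2 to compound 4 (0.21 log units; within the scatter), lies within the scatter, so on the methyl-bearing core shared by these two compounds the 2-fluorobenzyl group and the 3-chlorobenzyl group cannot be told apart. For the compounds shown here, earlier, the 2-fluorobenzyl group could be seen only in compound 1, which also differs in a second place; this step shows the exchange on its own, and this position accepts it without a change beyond the scatter. No measurement bears on why the two groups give such similar numbers.

Because the halogen and its place on the ring change together in this step, the compounds shown leave open what either change does alone, which a 2-chlorobenzyl group, a 3-fluorobenzyl group or a plain benzyl group could address, and they also leave open whether a group of another kind, such as a benzyl group carrying an amine or a carboxylic acid, would be accepted here. They also leave open whether the same exchange gives a similar step on the methoxy-bearing core of compound 3.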